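Series notes: truncation of the amide-capped chain in compound 2

A few compounds are considered here, and "the series" means these few. Any claim that something is new, unique, unknown or untested is made for them only; others in the source may bear on it.

Measured so far in an assay on isolated protein (Mus musculus) for inhibition of IL15-IL15 receptor (Homo sapiens), read by resazurin assay, with stated times of 30 min and 2.5 days; a lower number here means a stronger inhibitor, a higher number a weaker inhibitor:
- compound 1 `Cn1c(Cc2nn(C)c(=O)c3ccccc23)nnc1SCCCCCCCCCCCCCCCC(=O)Nc1ccc(Cl)cc1Cl`: 7300 nM
- compound 2 `Cn1c(Cc2nn(C)c(=O)c3ccccc23)nnc1SCCCCCCCCCCC(=O)Nc1ccc(Cl)cc1`: 20000 nM
- compound 3 `CC(C)COc1ccc(NC(=O)CSc2nnc(Cc3nn(C)c(=O)c4ccccc34)n2C)cc1`: 30000 nM

Compound 2 sits second highest of the three numbers. Its nearest neighbour is compound 3, whose value lies within the scatter of that of compound 2, so no order can be read between these two. Compound 1 stands furthest away, with a lower number that falls beyond the scatter; no single-point step connects compound 1 to compound 2, so the two values are simply shown side by side.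

The next compound is compound 4 `CCCCCCCCCCSc1nnc(Cc2nn(C)c(=O)c3ccccc23)n1C`. Relative to compound 2 the change is hydrogen in place of (4-chlorophenyl)carbamoyl on a saturated chain carbon, ten or more bonds along the chain from a sulfur. The entire aryl amide cap is thus cut away and a bare saturated chain ends the molecule.

Among the compounds with values here, no measured step of this type exists in the set. The three measured compounds all carry an aryl amide at the chain end, and the only one with a clearly lower number, compound 1, carries the largest such cap. The expectation for the step in this assay is a move towards a higher number, probably somewhat beyond the scatter, expressed as a 2.3-fold higher number from compound 2 to compound 4 (0.35 log units; beyond the scatter).

The value of compound 4 in this assay is therefore estimated at 45000 nM, within a range of 15000 nM to 120000 nM.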

Compound 4, half-maximal inhibitory concentration: 7600 nM
For compound 4 the middle estimate is 5.9-fold (0.77 log units) above the measured one, outside the stated range (below it).
By their numbers in this assay, from the lowest: compounds 1 and 4 (each within the scatter of the next); then compounds 2 and 3 (each within the scatter of the next).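

In this assay, cutting the (4-chlorophenyl)carbamoyl back to hydrogen gives a 2.6-fold lower number from compound 2 to compound 4 (0.42 log units; beyond the scatter), a modest step towards stronger inhibition and not a loss. Within the data shown here, on this saturated chain carbon, the aryl amide cap is therefore not needed for inhibition at this level, something the earlier compounds could not show while all of them carried such a cap. No supporting measurement is available to explain this step.

The single step removes the carbonyl, the amide hydrogen and the chlorophenyl ring together, so the compounds shown do not tell which of these parts accounts for the lower number. Also open, from the compounds shown here alone, is how the same chain behaves with a carboxylic acid, an amine or a simple phenyl ring at its end, and whether a shorter or longer bare chain moves the number further or returns it to the level of compound 2.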